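This account rests on a few compounds, and the source may have more. Where it says the series, first, only, none or still open, it means among the compounds named here.

Measured compounds:
- compound 1, `COc1cc(-c2cc(C(=O)/C=C/c3ccccc3)nc3cc(-c4ccccc4)nn23)cc(OC)c1OC`: 16300 nM
- compound 2, `COc1ccc(-c2cc(C(=O)/C=C/c3cc(OC)c(OC)c(OC)c3)nc3cc(-c4ccccc4)nn23)cc1OC`: 14700 nM

In a functional assay on DU-145 cells (Homo sapiens) for antiproliferative activity, read by MTT assay, with a stated time of 24 h (a lower number here means a stronger inhibitor, a higher number a weaker inhibitor), compound 1 gives 16300 nM, while compound 2 gives 14700 nM. Compound 2 holds the lower of the two numbers, yet the gap to compound 1 lies within the usual scatter, so the two compounds cannot be told apart on these data; both sit at weak inhibition.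

Compound 3, `COc1cc(/C=C/C(=O)c2cc(-c3cc(OC)c(OC)c(OC)c3)n3nc(-c4ccccc4)cc3n2)cc(OC)c1OC`, has not yet been measured. It differs from compound 2 by methoxy in place of hydrogen on an aromatic carbon, a small change that turns a 3,4-dimethoxyphenyl into a 3,4,5-trimethoxyphenyl. Going by the values given here, no measured pair shows this change, so its effect is unknown here. Because compound 2 gives 14700 nM and the change adds only a single methoxy, compound 3 is expected to show a step of a 1.1-fold lower number from compound 2 to compound 3 (0.05 log units; within the scatter) of no size beyond the scatter, in no clear direction. Compound 3 is therefore estimated at 13000 nM, with a range from 4500 nM to 38000 nM.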

Compound 3, half-maximal inhibitory concentration: 17900 nM
Compound 3: middle estimate off by 1.4-fold (0.14 log units), on the low side; low and high end bracket the measured number.
By their numbers in this assay, from the lowest: compounds 2, 1 and 3 (each within the scatter of the next).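

In this assay, methoxy in place of hydrogen on an aromatic carbon, which turns 3,4-dimethoxyphenyl into 3,4,5-trimethoxyphenyl, gives a 1.2-fold higher number from compound 2 to compound 3 (0.09 log units; within the scatter), so adding this methoxy brings no visible change. On the double-bonded chain, 3,4,5-trimethoxyphenyl in place of phenyl gives a 1.1-fold higher number from compound 1 to compound 3 (0.04 log units; within the scatter), so this larger swap also leaves the number within the scatter and all three compounds remain weak inhibitors. Nothing further is available that could explain this flat result.

On these data alone, only phenyl rings carrying methoxy groups or none are compared here, so it remains open whether an amine or a carboxylic acid at this position would move the number beyond the scatter. The same question stands for a longer chain, such as butoxy, in place of methoxy.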